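Exchanging the ring group of compound 2

The source may report more compounds than this note shows. Statements on the series, on what has been measured and on what is new or still open speak of the compounds shown alone.

Compound 1 `CN(C[C@H]1Cc2c(cccc2N2CCC(N)CC2)CN1)[C@H]1CCCc2cccnc21` gives 80.8%
Compound 2 `CN(C[C@H]1Cc2c(cccc2N2C[C@H]3CNC[C@H]3C2)CN1)[C@H]1CCCc2cccnc21` gives 86.7%
Compound 3 `CN1CCN(Nc2cccc3c2C[C@@H](CN(C)[C@H]2CCCc4cccnc42)NC3)CC1` gives 73.6%

In an ADME assay on microsomes from liver (Homo sapiens) for metabolic stability, using NADPH, with a stated time of 10 min (on this read-out higher numbers stand for a more stable compound and lower numbers for a less stable compound), compound 2 gives 86.7% and stands level with compound 1 within the scatter, while compound 3 lies lower, beyond the scatter. Compound 4 `CN(C)C1CCN(c2cccc3c2C[C@H](CN(C)[C@H]2CCCc4cccnc42)NC3)CC1` differs from compound 2 by a group of 9 heavy atoms (7 carbon, 2 nitrogen; one six-membered non-aromatic ring with 1 hetero atom) in place of a group of 8 heavy atoms (6 carbon, 2 nitrogen; 2 five-membered non-aromatic rings with 1 hetero atom each), on an aromatic carbon and the entering group is 4-(dimethylamino)piperidin-1-yl. Going by the values given here, the one measured step that bears on this is a number 5.9 percentage points higher from compound 1 to compound 2 (within the scatter) and it covers a similar exchange run the other way. Among the compounds with values here, no measured step covers the dimethylamino group itself. A small drop is therefore expected, with the estimated change a number 6.7 percentage points lower from compound 2 to compound 4 (within the scatter) and no move beyond the scatter. In this assay compound 4 is estimated at 80% with a range from 68% to 90% expected.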

Compound 4, percent of the compound remaining: 78.4%
Compound 4: middle estimate off by 1.6 percentage points, on the high side; measured number inside the range.
By their numbers in this assay, from the lowest: compounds 3, 4, 1 and 2 (each within the scatter of the next, the first and the last beyond it).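

In this assay, the exchange for 4-(dimethylamino)piperidin-1-yl on this aromatic carbon comes to a number 8.3 percentage points lower from compound 2 to compound 4 (within the scatter), so the entering group stands level with the group it replaces. Dimethylamino in place of amino on the saturated ring carbon comes to a number 2.4 percentage points lower from compound 1 to compound 4 (within the scatter), so the scatter does not separate the two piperidine compounds either. Nothing available here offers an explanation for these results. Open, going by these compounds, is whether a carboxylic acid on that saturated ring carbon, or a morpholin-4-yl group on the aromatic carbon, would stay level with these compounds.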